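The source may report more compounds than this note shows. Statements on the series, on what has been measured and on what is new or still open speak of the compounds shown alone.

Among the compounds with values here, in a functional assay on the whole organism (PC-3 cells) for inhibition, with Mus musculus as the target, in a xenograft, with a stated time of 24 h, at a dose of 100 mg/kg by the oral route (a higher number here means more inhibition at the dose given (going by the name of the read-out), a lower number less inhibition), compound 1 `CC(C)(O)c1ccc(-c2cnc3c(n2)N(CCC2CCOCC2)C(=O)CN3)cn1` gives 69% and compound 2 `CC(C)(O)c1ccc(-c2cnc3c(n2)N(CC2CCOCC2)C(=O)CN3)cn1` gives 80%; the only step between measured compounds is a number 11 percentage points higher from compound 1 to compound 2 (beyond the scatter). Compound 3 `CO[C@H]1CC[C@@H](N2CC(=O)Nc3ncc(-c4ccc(C(C)(C)O)nc4)nc32)CC1` gives 45% in this assay, the lowest of the three numbers, beyond the scatter below both compound 1 and compound 2. Compound 4 `CO[C@H]1CC[C@H](N2CC(=O)Nc3ncc(-c4ccc(C(C)(C)O)nc4)nc32)CC1` differs from compound 3 only in configuration: the two compounds have the same atoms and bonds and differ only in configuration as drawn: 2 of 2 stereo elements differ (all stereocentres are inverted: mirror images); a stereocentre at a saturated ring carbon is drawn s in compound 3 and r in compound 4; a stereocentre at a saturated ring carbon is drawn s in compound 3 and r in compound 4. Within the data shown here, no measured step concerns an inversion of stereocentres; the single measured step changes a different part of the molecule and offers no guide to direction. With nothing pointing either way, the step expected in this assay is a number 3 percentage points higher from compound 3 to compound 4 (within the scatter), within the scatter but with wide uncertainty. Compound 4 is therefore estimated at 48%, between 20% and 75%.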

Compound 4, a percentage reported as inhibition, in the whole organism at one dose (the size of the read-out at that dose, not a potency): 61%
Beside the measured number, compound 4's estimate is 13 percentage points below it; the measured number falls inside the stated range.
By their numbers in this assay, from the lowest: compound 3; then compounds 4 and 1 (each within the scatter of the next); then compound 2.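

In this assay there is a number 16 percentage points higher from compound 3 to compound 4 (beyond the scatter), so configuration at the saturated ring carbons alone can shift this read-out, which the earlier step, a change in the chain on the amide-type nitrogen, could not show. No atom enters or leaves, so the step can be ascribed to configuration alone, because of this: the fact that compounds 3 and 4 differ only in the configuration as drawn

The compounds shown leave open whether configuration matters to the same degree when a hydroxyl group or an amine replaces the methoxy group on that ring. They also do not show why this configuration gives the higher number.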